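Removing One Methoxy Group from the Ketone Side of Compound 2

The source may hold more compounds than are shown below. What is called first, only, known or untested is meant among the compounds shown, and "the series" means these compounds.

Compound 2 `COc1ccc(C(=O)/C=C/c2cc(-c3cc(OC)c(OC)c(OC)c3)n[nH]2)cc1OC` was tested in a functional assay on HT-29 cells (Homo sapiens) for inhibition, read by sulforhodamine B assay, with a stated time of 48 h (a higher number here means a weaker inhibitor of growth, a lower number a stronger inhibitor of growth), where compound 2 gives 1620 nM. Its only companion, compound 1 `COc1cc(-c2cc(/C=C/C(=O)c3ccc(Cl)c(Cl)c3)[nH]n2)cc(OC)c1OC`, gives 1150 nM in this assay, and the step of a 1.4-fold higher number from compound 1 to compound 2 (0.15 log units; within the scatter) leaves the two numbers indistinguishable, so compound 2 holds the higher of the two numbers without separating from compound 1. The new compound 3 `COc1ccc(C(=O)/C=C/c2cc(-c3cc(OC)c(OC)c(OC)c3)n[nH]2)cc1` differs from compound 2 by hydrogen in place of methoxy on an aromatic carbon. Among the compounds with values here, no measured pair removes a methoxy from this ring; the single step in hand exchanges 3,4-dichlorophenyl for 3,4-dimethoxyphenyl and stays within the scatter, so the numbers offer no direction for the present change. On that slim basis compound 3 is expected to sit close to compound 2, with an estimated step of a 1.1-fold higher number from compound 2 to compound 3 (0.05 log units; within the scatter) that is not expected to exceed the scatter. The estimate for compound 3 in this assay is 1800 nM, within a range from 700 nM to 4500 nM.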

Compound 3, concentration for 50% growth inhibition: 1970 nM
Beside the measured number, compound 3's estimate is 1.1-fold (0.04 log units) below it; the range from low to high includes it.
By their numbers in this assay, from the lowest: compounds 1, 2 and 3 (each within the scatter of the next).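

In this assay, going from 3,4-dimethoxyphenyl to 4-methoxyphenyl gives a 1.2-fold higher number from compound 2 to compound 3 (0.08 log units; within the scatter), so hydrogen can stand in place of methoxy at this position, ortho to a methoxy group and meta to a large group, without the numbers separating. The exchange of 3,4-dichlorophenyl for 4-methoxyphenyl on the carbonyl carbon gives a 1.7-fold higher number from compound 1 to compound 3 (0.23 log units; within the scatter), which leaves all three groups at that carbonyl carbon within the scatter of one another. Nothing available explains why these changes leave the numbers so close.

Going by these compounds, whether an amine, a carboxylic acid or a longer chain at this position would move the number beyond the scatter stays open. On these data alone, it is also open whether losing the methoxy that remains on this ring would do so.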